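The source may hold more compounds than are shown below. What is called first, only, known or untested is meant among the compounds shown, and "the series" means these compounds.

Measured so far in a functional assay on U-251 cells (Homo sapiens) for inhibition, read by sulforhodamine B assay, with a stated time of 48 h; a higher number here means a weaker inhibitor of growth, a lower number a stronger inhibitor of growth:
compound 1 `CC1=CC[C@H](C(C)(C)NC(=S)N/N=C/c2ccc[nH]2)CC1` gives 80 nM
compound 2 `CC1=CC[C@H](C(C)(C)NC(=S)N/N=C(\C)c2ccccc2)CC1` gives > 100000 nM
compound 3 `COc1ccc(/C(C)=N/NC(=S)NC(C)(C)[C@H]2CC=C(C)CC2)cc1` gives 43400 nM.

The value of compound 2 is a limit of this assay, not a number. Compound 3 stands highest of the two numbers; compound 1 lies far lower. Going by the values given here, the one measured step is an at least 2.3-fold lower number from compound 2 to compound 3 (0.36 log units; beyond the scatter), methoxy in place of hydrogen on an aromatic carbon.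

Compound 4 `CC1=CC[C@H](C(C)(C)NC(=S)N/N=C(\C)c2ccc([N+](=O)[O-])cc2)CC1` differs from compound 3 by nitro in place of methoxy on an aromatic carbon. Among the compounds with values here, only the step from compound 2 to compound 3 bears on this position, and it was modest. A step of similar size or none beyond the scatter is therefore expected in this assay, direction open. Compound 4 is estimated at 40000 nM, range 10000 nM to 120000 nM, an expected step of a 1.1-fold lower number from compound 3 to compound 4 (0.04 log units; within the scatter).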

Compound 4, concentration for 50% growth inhibition: 7000 nM
Compound 4: middle estimate off by 5.7-fold (0.76 log units), on the high side; the measured number lies below the stated range.
By their numbers in this assay, from the lowest: compound 1; then compound 4; then compound 3. At a limit, above all of these: compound 2.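

Nitro at this position, para to a large group, gives a 6.2-fold lower number from compound 3 to compound 4 (0.79 log units; beyond the scatter), so exchanging one substituent for another here moves the number beyond the scatter. Against hydrogen, nitro gives an at least 14-fold lower number from compound 2 to compound 4 (1.15 log units; beyond the scatter). The value of compound 2 is a limit, not a number: the limit of > 100000 nM in this assay, at which 1 of the 4 values shown sits.

Going by these compounds, whether an amine or a carboxylic acid at this position would give a lower or higher number stays open. Also open, on these data alone, is how a chloro group would compare with nitro and methoxy on the shared core.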